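Chloro in place of hydrogen on compound 3

The source may report more compounds than this note shows. Statements on the series, on what has been measured and on what is new or still open speak of the compounds shown alone.

Values in a functional assay on Bel-7402 cells (Homo sapiens) for inhibition, read by MTT assay, with a stated time of 24 h, tested at 100 ug/mL (on this read-out lower numbers stand for less inhibition of growth and higher numbers for more inhibition of growth at the one concentration tested), stand as follows:
Compound 1 `CC(=O)SCCC(CCCCC(=O)O)SC(C)=O` gives 8.35%
Compound 2 `O=C(CCCCC1CCSS1)Nc1cccc2ccccc12` gives 7.22%
Compound 3 `CC(=O)SCCC(CCCCC(=O)Nc1ccccc1)SC(C)=O` gives 14.1%

Compound 3, at 14.1%, lies within the scatter of compound 1 and compound 2, so no order can be read among the three. Compound 4 `CC(=O)SCCC(CCCCC(=O)Nc1ccccc1Cl)SC(C)=O` carries chloro in place of hydrogen on an aromatic carbon, ortho to a large group (chloro in place of hydrogen on an aromatic carbon). Among the measured compounds shown here, the one measured step, a number 5.8 percentage points higher from compound 1 to compound 3 (within the scatter), bears only indirectly, since it changes a carbonyl carbon, and no measured step tests a chloro group. An estimated a number 1.9 percentage points higher from compound 3 to compound 4 (within the scatter) is therefore expected in this assay, with no step beyond the scatter. For compound 4 the estimate is 16% (expected range 7% to 32%).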

Compound 4, percent growth inhibition at one concentration: "not active" (no number reported)
Nothing numeric was reported for compound 4, so the estimate cannot be set against anything.
By their numbers in this assay, from the lowest: compounds 2, 1 and 3 (each within the scatter of the next).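

Among the compounds shown here, compound 4 was reported as "not active" without a number in this assay, so no step from compound 3 to compound 4 can be read. The compounds shown leave open what chloro in place of hydrogen does to growth inhibition, and no evidence bears on this result.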